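Methoxy on the fused ring of compound 3

The compounds below may be only part of what the source reports. "The series", "measured", "known", "first", "only" and "open" are said of these compounds alone.

Three compounds carry the shared trifluoromethoxybenzamide. Compound 1 `CC(C)(C)c1ccc(NC(=O)c2ccc(OC(F)(F)F)cc2)cc1` is the anilide; in a functional assay on HEK293 cells for antagonist activity at transient receptor potential cation channel subfamily V member 1 (Homo sapiens), read by calcium flux (on this read-out higher numbers stand for weaker inhibition and lower numbers for stronger inhibition), compound 1 gives 120 nM. Compound 2 `O=C(NCCN1CCCc2ccccc21)c1ccc(OC(F)(F)F)cc1` and compound 3 `O=C(NCCn1ccc2ccccc21)c1ccc(OC(F)(F)F)cc1` replace the anilide with an ethylene-linked fused bicyclic amine: in this assay compound 2 gives 4600 nM and compound 3 gives 7300 nM.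

Among the three numbers, compound 3 and compound 2 sit within the scatter of each other, so they are not separated by these data; compound 1 lies far beyond the scatter at a much lower number, the only clear distinction in the set.

Compound 4 `COc1ccc2ccn(CCNC(=O)c3ccc(OC(F)(F)F)cc3)c2c1` is compound 3 with methoxy in place of hydrogen on an aromatic carbon. Within the data shown here, no measured pair isolates such a change, so no step size can be read off. The values of compound 2 and compound 3 suggest that the bicyclic amides cluster in one range, and a single methoxy is expected to move the number little: the step from compound 3 to compound 4 is expected to be a 1.2-fold lower number from compound 3 to compound 4 (0.09 log units; within the scatter), at most a small shift in either direction, probably within the scatter.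

In this assay compound 4 is therefore estimated at 6000 nM, within a range from 2500 nM to 15000 nM.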

Compound 4, half-maximal inhibitory concentration: 3550 nM
Beside the measured number, compound 4's estimate is 1.7-fold (0.23 log units) above it, within the range that was stated.
By their numbers in this assay, from the lowest: compound 1; then compounds 4, 2 and 3 (each within the scatter of the next, the first and the last beyond it).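

In this assay the series now has its first step that isolates one change: methoxy in place of hydrogen on an aromatic carbon of the six-membered aromatic ring of carbon only gives a 2.1-fold lower number from compound 3 to compound 4 (0.31 log units; beyond the scatter), a modest step that lies just beyond the scatter. This position therefore tolerates methoxy, with its 2 heavy atoms and 1 hydrogen-bond acceptor, with no loss of inhibition and a small gain, which compound 2 and compound 3 alone could not show. Nothing at hand explains the gain, so the step stands as an observation without a known cause.

The compounds shown leave open whether the gain is specific to methoxy or would also appear with a hydroxyl, an ethoxy, a fluorine or an amine on the same carbon, and a longer alkoxy chain would show whether more size at this position is still accepted. Also open, going by these compounds, is whether the other carbons of this ring respond in the same way, since a single substituted position gives no trend around the ring.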